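Replacing nitro with methoxy: how large a step?

The compounds below may be only part of what the source reports. "The series", "measured", "known", "first", "only" and "open" are said of these compounds alone.

Among the measured compounds shown here, in a functional assay on KB-VIN10 cells (Homo sapiens) for inhibition, with a stated time of 72 h (on this read-out lower numbers stand for stronger inhibition and higher numbers for weaker inhibition), compound 1 `COc1ccc(S(=O)(=O)N2CCc3cccc(-c4ccc([N+](=O)[O-])cc4)c32)cc1` gives 51.3 nM and stands at the low end of the numbers so far. Compound 3 `COc1ccc(S(=O)(=O)N2CCc3cccc(-c4ccc(F)cc4)c32)cc1` gives 94.6 nM and lies within the scatter of it, while compound 2 `COc1ccc(S(=O)(=O)N2CCc3cccc(-c4cc(OC)c(OC)c(OC)c4)c32)cc1` sits far higher at 4670 nM on the same read-out.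

Compound 4 `COc1ccc(-c2cccc3c2N(S(=O)(=O)c2ccc(OC)cc2)CC3)cc1` has methoxy in place of nitro on an aromatic carbon, so that 4-nitrophenyl becomes 4-methoxyphenyl (methoxy in place of nitro on an aromatic carbon). The closest guide is a change at that same place, with fluoro in place of nitro: a 1.8-fold higher number from compound 1 to compound 3 (0.27 log units; within the scatter) and so no clear shift. Compound 2 also carries methoxy on that ring, along with further methoxy groups, and its 4670 nM keeps the high side of the estimate wide.

A small upward move is therefore expected, with a 1.8-fold higher number from compound 1 to compound 4 (0.24 log units; within the scatter) as the estimated step, which is about the size of the scatter. In this assay compound 4 is expected at 90 nM with an estimated range from 25 nM to 450 nM as its likely span.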

Compound 4, half-maximal inhibitory concentration: 352 nM
The estimate for compound 4 lay 3.9-fold (0.59 log units) below the measured number; the measured number falls inside the stated range.
By their numbers in this assay, from the lowest: compounds 1 and 3 (each within the scatter of the next); then compound 4; then compound 2.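

The group at this position does matter in this assay, which the earlier step between nitro and fluoro could not show. Methoxy in place of nitro gives a 6.9-fold higher number from compound 1 to compound 4 (0.84 log units; beyond the scatter), and methoxy in place of fluoro gives a 3.7-fold higher number from compound 3 to compound 4 (0.57 log units; beyond the scatter), so both steps point to weaker inhibition with methoxy, and both are beyond the scatter though modest in size. No measurement is available that explains why methoxy parts from the other two groups.

From the compounds shown here alone, only nitro, fluoro and methoxy can be compared singly at this place on the shared core, so it remains open how an amine, a carboxylic acid or a nitrile would read out there. Going by these compounds, whether the methoxy step would keep its size on a different core also remains open.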